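The source may hold more compounds than are shown below. What is called first, only, known or untested is meant among the compounds shown, and "the series" means these compounds.

Compound 2 `CC(C)(C)Sc1c(CC(C)(C)C(=O)O)n(Cc2ccc(Cl)cc2)c2ccc(OCc3cc4ccccc4cn3)cc12` is examined in a functional assay (blood) for inhibition, with Homo sapiens as the target; a lower number here means a stronger inhibitor, a higher number a weaker inhibitor. In this assay compound 2 gives > 3000 nM, which is a limit of the assay rather than a measured number. Within the data shown here, the only other measured compound is compound 1 `CC(C)(C)Sc1c(CC(C)(C)C(=O)O)n(Cc2ccc(Cl)cc2)c2ccc(CCc3ccc4ccccc4n3)cc12`, which differs from compound 2 in a single place. In this assay compound 1 gives > 3000 nM, likewise a limit. The step that the two limits leave unreadable from compound 1 to compound 2 therefore has no readable size because of the limit of > 3000 nM in this assay, at which 2 of the 2 values shown sit.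

Compound 3 `Cc1nc2ccc(COc3ccc4c(c3)c(SC(C)(C)C)c(CC(C)(C)C(=O)O)n4Cc3ccc(Cl)cc3)cc2s1` differs from compound 2 by 2-methyl-1,3-benzothiazol-6-yl in place of isoquinolin-3-yl on a saturated chain carbon bound to an oxygen on an aromatic ring. Among the measured compounds shown here, no measured step touches this part of the molecule, and the one step that exists carries no size, so neither direction nor size can be drawn from the data. Compound 3 is therefore expected to stay close to where compound 2 stands, with the expected step being a step that the limit leaves unreadable from compound 2 to compound 3. The estimate for compound 3 is 5000 nM, within a range from 1500 nM to 30000 nM.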

Compound 3, half-maximal inhibitory concentration: > 3000 nM
Compound 3: a limit, no number; the forecaster's own chance of this, stated with the estimate: 70%; the middle value is on the limit's open side.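

Compound 1, compound 2 and compound 3 all give a limit rather than a number, so no step among them can be read: the limit of > 3000 nM in this assay, at which 3 of the 3 values shown sit.

The compounds shown leave open how strongly each one inhibits, and whether 2-methyl-1,3-benzothiazol-6-yl and isoquinolin-3-yl differ in their effect at all.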